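The compounds below may be only part of what the source reports. "The series", "measured", "known", "first", "only" and "open" are said of these compounds alone.

Measured compounds:
Compound 1 `Fc1ccc(-c2cn3ccnc3c(-c3ccc4ncn(C5CCCCC5)c4c3)n2)cc1` gives 24.7% in a functional assay on K562 cells (Homo sapiens) for inhibition, read by sulforhodamine B assay, with a stated time of 48 h, tested at 10 uM; on this read-out lower numbers stand for less inhibition and higher numbers for more inhibition at the one concentration tested (going by the name of the read-out).
Compound 2 `COc1ccccc1-c1cn2ccnc2c(-c2ccc3ncn(C4CCCCC4)c3c2)n1` gives 22.6% in this assay.

Both measured compounds share one core and differ only in the aryl group attached to it. The step of a number 2.1 percentage points lower from compound 1 to compound 2 (within the scatter) lies within the scatter, so compound 2 and compound 1 cannot be told apart on this read-out; compound 2 therefore stands alongside the only other number shown rather than apart from it.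

Compound 3 `FC(F)(F)c1cccc(-c2cn3ccnc3c(-c3ccc4ncn(C5CCCCC5)c4c3)n2)c1` has not yet been measured. It differs from compound 2 in 3-(trifluoromethyl)phenyl in place of 2-methoxyphenyl on an aromatic carbon. Among the measured compounds shown here, only one measured step bears on this change, and it does so loosely: it exchanges one aryl group for another at the same place, and that exchange, a number 2.1 percentage points lower from compound 1 to compound 2 (within the scatter), produced nothing beyond the scatter. Nothing in the two measurements suggests that a third aryl group at this place should move the read-out in either direction, and nothing rules it out either. The step of a number 0.4 percentage points higher from compound 2 to compound 3 (within the scatter) is therefore expected to stay within the scatter. Compound 3 is estimated to give 23% in this assay, within a range from 10% to 38%.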

Compound 3, a percentage reported as inhibition, at one concentration (the size of the read-out at that concentration, not a potency): 21.5%
Compound 3: middle estimate off by 1.5 percentage points, on the high side; measured number inside the range.
By their numbers in this assay, from the lowest: compounds 3, 2 and 1 (each within the scatter of the next).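

In this assay the exchange of 2-methoxyphenyl for 3-(trifluoromethyl)phenyl gives a number 1.1 percentage points lower from compound 2 to compound 3 (within the scatter) and stays within the scatter, as does the exchange of 4-fluorophenyl for the same group, which gives a number 3.2 percentage points lower from compound 1 to compound 3 (within the scatter) on this read-out. Where the earlier pair offered a single exchange at this place, three differently substituted phenyl groups can now be compared there, and none can be told apart from the others, even though the entering group brings fluorine and has no hydrogen-bond acceptor, while 2-methoxyphenyl has one. No measurement is available that would explain why these three aryl groups read alike.

Going by these compounds, all three compounds carry a six-membered aromatic ring of carbon only at this place, so it remains open whether an amine, a carboxylic acid or a longer chain there would move the read-out beyond the scatter. The rest of the shared core is identical across the three, and so these compounds say nothing about how a change elsewhere on it would register.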